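A few compounds are considered here, and "the series" means these few. Any claim that something is new, unique, unknown or untested is made for them only; others in the source may bear on it.

Three compounds share one core and were tested in a functional assay on SGC-7901 cells (Homo sapiens) for antiproliferative activity, read by MTT assay, with a stated time of 48 h; on this read-out higher numbers stand for weaker inhibition and lower numbers for stronger inhibition. Compound 1 `Cc1ccccc1-c1nnc(SCc2ccc(Cl)nc2)o1` gives 8.51 ug/mL, compound 2 `CN(C)c1ccc(-c2nnc(SCc3ccc(Cl)nc3)o2)cc1` gives 8.9 ug/mL, and compound 3 `COc1ccc(-c2nnc(SCc3ccc(Cl)nc3)o2)c(OC)c1OC` gives 10.2 ug/mL. Among the compounds with values here, compound 1 has the lowest number of the three, yet all three sit within the scatter of one another, so no compound can be called stronger than another. Compound 4 `Clc1ccc(CSc2nnc(-c3ccco3)o2)cn1` has not yet been measured. It differs from compound 1 in one place: furan-2-yl in place of 2-methylphenyl on an aromatic carbon. Within the data shown here, no measured pair shows a change of this kind, so there is no step to lean on. The three measured values lie very close together. The expected step is therefore small, a 1.1-fold higher number from compound 1 to compound 4 (0.05 log units; within the scatter), within the scatter. Compound 4 is expected to give about 9.5 ug/mL, between 5 ug/mL and 18 ug/mL.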

Compound 4, half-maximal inhibitory concentration: 14.3 ug/mL
Estimate against measurement, compound 4: 1.5-fold (0.18 log units) below, and the stated range covers the measured number.
By their numbers in this assay, from the lowest: compounds 1, 2, 3 and 4 (each within the scatter of the next).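

In this assay, furan-2-yl in place of 2-methylphenyl gives a 1.7-fold higher number from compound 1 to compound 4 (0.23 log units; within the scatter), so no difference between the two groups can be claimed. On this carbon of the shared core, a five-membered aromatic ring with one oxygen therefore reads the same as a six-membered all-carbon ring, within the scatter. Nothing measured here bears on how either group acts in the cells. Every group shown on this carbon is an aromatic ring. On these data alone, whether an amine, a carboxylic acid or a longer chain there would give a number beyond the scatter of compound 1 remains open.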